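This account rests on a few compounds, and the source may have more. Where it says the series, first, only, none or still open, it means among the compounds named here.

Measured in a functional assay on UACC-62 cells (Homo sapiens) for inhibition; on this read-out lower numbers stand for stronger inhibition of growth and higher numbers for weaker inhibition of growth:
- compound 1 `COc1ccc(-n2cnnc2-c2cc(OC)c(OC)c(OC)c2)cc1`: 3240 nM
- compound 2 `COc1cc(-c2nncn2-c2ccc(N(C)C)cc2)cc(OC)c1OC`: 95.5 nM

Of these two, compound 1 has the higher number and so the weaker inhibition of growth. The next compound, compound 3 `COc1ccc(-n2cnnc2-c2cc(OC)c(OC)c(OC)c2)cc1O`, is compound 1 with one change: hydroxy in place of hydrogen on an aromatic carbon, ortho to a methoxy group.

For the measured compounds named here, only one measured step bears on this, and only indirectly. In a 34-fold lower number from compound 1 to compound 2 (1.53 log units; beyond the scatter), a large change beyond the scatter, dimethylamino replaced methoxy on an aromatic carbon. Going by the values given here, that shows that this assay can respond strongly to a single substitution on an aromatic carbon, but no measured compound carries a hydroxy group. A lower number is therefore expected, with a step that is probably smaller and quite uncertain: the expected change is an 8.1-fold lower number from compound 1 to compound 3 (0.91 log units; beyond the scatter). For compound 3 the estimated value is 400 nM, with an expected range of 50 nM to 3000 nM.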

Compound 3, concentration for 50% growth inhibition: 407 nM
Estimate against measurement, compound 3: 1.0-fold (0.01 log units) below, within the range that was stated.
By their numbers in this assay, from the lowest: compound 2; then compound 3; then compound 1.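

In this assay, putting hydroxy on this aromatic carbon, ortho to a methoxy group, gives an 8.0-fold lower number from compound 1 to compound 3 (0.90 log units; beyond the scatter) and so counts as a modest step. The position, which carries only hydrogen in compound 1, therefore tolerates a new group, and here a single added oxygen atom is enough to strengthen inhibition of growth beyond the scatter. Nothing shown here explains why the number falls.

The compounds shown leave open whether an amine, a fluorine atom or an ethoxy group on the same carbon would give a similar step, so the role of hydroxy itself remains unsettled. On these data alone, it also remains open whether this hydroxy group and the dimethylamino group of compound 2 would add up in a single compound.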